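Chromanone series: removing the benzyl group from the aryl ether oxygen

The source may report more compounds than this note shows. Statements on the series, on what has been measured and on what is new or still open speak of the compounds shown alone.

Measured compounds:
compound 1 `CCCOc1ccccc1C1CC(=O)c2ccccc2O1` — 43.6%
compound 2 `CC(C)c1ccc(COc2ccccc2C2CC(=O)c3ccccc3O2)cc1` — 91.7%

Compound 2 stands highest of the two numbers in a functional assay on J774.A1 cells (Mus musculus) for inhibition, read by immunoassay, with a stated time of 12 h, tested at 30 uM; on this read-out lower numbers stand for less inhibition and higher numbers for more inhibition at the one concentration tested (going by the name of the read-out); its nearest neighbour is compound 1, which in this assay gives 43.6%. Going by the values given here, the only measured step is a number 48.1 percentage points higher from compound 1 to compound 2 (beyond the scatter), a large gain on exchanging the ethyl for the 4-isopropylphenyl.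

Compound 3 `COc1ccccc1C1CC(=O)c2ccccc2O1` is the next member to be measured. It differs from compound 2 by hydrogen in place of 4-isopropylphenyl on a saturated chain carbon bound to an oxygen on an aromatic ring. Among the compounds with values here, the single measured step bears on it only indirectly: it shows that the 4-isopropylphenyl, once present at this place, goes with a large rise, so its loss is expected to reverse most of that rise and to bring compound 3 close to where compound 1 sits.

Compound 3 is therefore estimated at 38% in this assay, within 18% to 62%, which is a step of a number 53.7 percentage points lower from compound 2 to compound 3 (beyond the scatter) expected to lie beyond the scatter.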

Compound 3, a percentage reported as inhibition, at one concentration (the size of the read-out at that concentration, not a potency): 38.3%
Compound 3: middle estimate off by 0.3 percentage points, on the low side, within the range that was stated.
By their numbers in this assay, from the lowest: compounds 3 and 1 (each within the scatter of the next); then compound 2.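

In this assay, hydrogen in place of 4-isopropylphenyl gives a number 53.4 percentage points lower from compound 2 to compound 3 (beyond the scatter) and thus confirms from a second comparison that the standing of compound 2 goes with that group on the saturated chain carbon bound to an oxygen on an aromatic ring. Hydrogen in place of ethyl gives a number 5.3 percentage points lower from compound 1 to compound 3 (within the scatter), so ethyl and hydrogen cannot be told apart at this place, and among the compounds shown only the 4-isopropylphenyl separates from the others. Nothing available explains this difference.

Open, going by these compounds, is whether the step needs the aromatic ring alone or also its isopropyl, which a plain phenyl would separate. Also open, on these data alone, is how a longer chain such as butyl, or an amine on the chain, would compare with ethyl and 4-isopropylphenyl.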